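The source may report more compounds than this note shows. Statements on the series, on what has been measured and on what is new or still open speak of the compounds shown alone.

Compound 1 `Cc1ccc(Nc2nc(SCc3cn(CC(=O)NC(=O)Nc4ccccn4)nn3)nc(-c3ccc(C(C)C)cc3)c2C#N)cc1` and compound 2 `Cc1cccc(Nc2nc(SCc3cn(CC(=O)NC(=O)Nc4ccccn4)nn3)nc(-c3ccc(C(C)C)cc3)c2C#N)c1` share one core and differ only in the aryl group carried on the nitrogen on the aromatic ring. In a functional assay on MCF7 cells (Homo sapiens) for inhibition, read by MTT assay, with a stated time of 72 h (on this read-out higher numbers stand for weaker inhibition and lower numbers for stronger inhibition), compound 1 gives > 64000 nM, which is a limit of the assay rather than a number. In this assay compound 2 likewise gives > 64000 nM, again a limit of the assay and not a number. The step that the two limits leave unreadable from compound 1 to compound 2 therefore cannot be read, since both of its ends sit at the limit of > 64000 nM in this assay, at which 2 of the 2 values shown sit. Compound 2 thus stands at that limit, and the numbers shown give nothing to separate it from compound 1.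

Compound 3 `COc1ccccc1Nc1nc(SCc2cn(CC(=O)NC(=O)Nc3ccccn3)nn2)nc(-c2ccc(C(C)C)cc2)c1C#N` is reached from compound 2 by the change (2-methoxyphenyl in place of 3-methylphenyl on a nitrogen on an aromatic ring). Among the compounds with values here, the only measured step, the one from compound 1 to compound 2, is unreadable, so it offers no guide to the size or direction of the step to compound 3 in this assay. For compound 3 the expected value is therefore again most likely a limit, estimated at 100000 nM, with a range from 30000 nM to 300000 nM. The step that the limit leaves unreadable from compound 2 to compound 3 implied by this estimate is expected to be none beyond the scatter.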

Compound 3, half-maximal inhibitory concentration: 19300 nM
Compound 3: the middle estimate sits 5.2-fold (0.71 log units) above what was measured; measured number below the stated range.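

The aryl group on the nitrogen on the aromatic ring proves able to move the read-out off the limit: in this assay, 2-methoxyphenyl in place of 3-methylphenyl gives an at least 3.3-fold lower number from compound 2 to compound 3 (0.52 log units; beyond the scatter), and 2-methoxyphenyl in place of 4-methylphenyl gives an at least 3.3-fold lower number from compound 1 to compound 3 (0.52 log units; beyond the scatter). Each of these steps starts from a limit, so each fixes a direction and a smallest possible size but no exact size. Compound 3 is the only one of the three with a read-out that is a number, while the two methylphenyl compounds remain unseparated: the limit of > 64000 nM in this assay, at which 2 of the 3 values shown sit.

The change replaces methyl with methoxy and alters the group's place on the ring in one move, so the compounds shown do not tell which of the two accounts for the step, and a 2-methylphenyl or a 3-methoxyphenyl group would be needed to part them. They also leave open how far the read-out in this assay would shift with a longer 2-ethoxyphenyl group or with an unsubstituted phenyl.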